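This account rests on a few compounds, and the source may have more. Where it says the series, first, only, none or still open, it means among the compounds named here.

In a functional assay on U-373MG ATCC cells (Homo sapiens) for inhibition, read by MTT assay, with a stated time of 72 h (a higher number here means a weaker inhibitor, a lower number a stronger inhibitor), compound 1 `CC1(C)CC(NC(=S)Nc2ccc(C#N)cc2)c2cc(F)ccc2O1` gives 11000 nM and compound 2 `CC1(C)CC(NC(=S)Nc2cccc(C#N)c2)c2cc(F)ccc2O1` gives 30000 nM as its value, so compound 1 holds the lower, stronger number of the pair. The next structure is compound 3 `CC1(C)CC(NC(=S)Nc2ccc([N+](=O)[O-])cc2)c2cc(F)ccc2O1`, which keeps the core of compound 1 and carries nitro in place of cyano on an aromatic carbon, para to a large group (nitro in place of cyano on an aromatic carbon). Among the compounds with values here, the one measured step that bears on this is a 2.7-fold higher number from compound 1 to compound 2 (0.44 log units; beyond the scatter) for 3-cyanophenyl in place of 4-cyanophenyl, a modest change. That step moves the cyano group and does not replace it, so no measurement here shows what nitro does. With so little to go on, no clear shift in this assay is expected in either direction. The estimated step is a 1.1-fold higher number from compound 1 to compound 3 (0.04 log units; within the scatter) and it carries wide uncertainty. For compound 3 the expected value is 12000 nM with an estimated range from 4000 nM to 35000 nM in this measurement.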

Compound 3, half-maximal inhibitory concentration: 3000 nM
Estimate against measurement, compound 3: 4.0-fold (0.60 log units) above; the measured number lies below the stated range.
By their numbers in this assay, from the lowest: compound 3; then compound 1; then compound 2.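

In this assay, nitro in place of cyano on an aromatic carbon, para to a large group, gives a 3.7-fold lower number from compound 1 to compound 3 (0.56 log units; beyond the scatter), a step beyond the usual scatter. Within the data shown here, the earlier pair showed only that moving the cyano group changes the number, whereas this step shows that changing the group itself, with its place on the ring kept, also changes it, here towards a stronger inhibitor. Nothing measured here accounts for this difference between nitro and cyano.

The compounds shown leave open how other groups at this place, such as an amine, a carboxylic acid or a methoxy group, would compare with nitro and cyano. They also leave open whether nitro would keep its lower number at another place on the ring.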